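The source may report more compounds than this note shows. Statements on the series, on what has been measured and on what is new or still open speak of the compounds shown alone.

Measured in a functional assay on MCF7 cells (Homo sapiens) for inhibition, read by MTT assay; on this read-out higher numbers stand for weaker inhibition of growth and lower numbers for stronger inhibition of growth:
compound 1 `COc1cc2oc(-c3cccc(NC(=O)c4cccc(Br)c4)c3)cc(=O)c2c(OC)c1OC`: 6340 nM
compound 2 `COC(=O)c1ccc(C(=O)Nc2cccc(-c3cc(=O)c4c(OC)c(OC)c(OC)cc4o3)c2)cc1`: 30300 nM

Compound 2 holds the higher of the two numbers, so it is the weaker growth inhibitor of this pair. Compound 3 `COc1cc2oc(-c3cccc(NC(=O)c4ccc(C)cc4)c3)cc(=O)c2c(OC)c1OC` has not yet been measured. It differs from compound 2 by methyl in place of methoxycarbonyl on an aromatic carbon, para to a large group. For the measured compounds named here, one measured step bears on this change: a 4.8-fold higher number from compound 1 to compound 2 (0.68 log units; beyond the scatter), a modest step in which 4-(methoxycarbonyl)phenyl stands in place of 3-bromophenyl on a carbonyl carbon. This is a single pair, and neither compound carries methyl. With the methoxycarbonyl gone, a lower number is expected in this assay, of similar or smaller size than that step. The expected change is a 2.5-fold lower number from compound 2 to compound 3 (0.40 log units; beyond the scatter). Compound 3 is estimated at 12000 nM, with an expected range of 4500 nM to 30000 nM.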

Compound 3, concentration for 50% growth inhibition: 8320 nM
Compound 3: the middle estimate sits 1.4-fold (0.16 log units) above what was measured; the range from low to high includes it.
By their numbers in this assay, from the lowest: compounds 1 and 3 (each within the scatter of the next); then compound 2.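

In this assay, methyl in place of methoxycarbonyl on the aromatic carbon para to a large group gives a modest step (a 3.6-fold lower number from compound 2 to compound 3 (0.56 log units; beyond the scatter)), which isolates the methoxycarbonyl as a change at this one place, whereas the earlier step (a 4.8-fold higher number from compound 1 to compound 2 (0.68 log units; beyond the scatter)) also exchanged 3-bromophenyl. The 4-methylphenyl and 3-bromophenyl amides are not separated (a 1.3-fold higher number from compound 1 to compound 3 (0.12 log units; within the scatter)), so among these three compounds only compound 2, the methoxycarbonyl compound, stands apart with the higher number. No measured evidence gives a reason for this difference.

As far as these compounds go, whether the higher number is specific to the methyl ester remains open, as a free carboxylic acid, an amine or a longer chain at the same place could each behave differently. The unsubstituted phenyl amide would also be needed to show whether methyl itself contributes.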